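Swapping thiophen-2-yl for furan-3-yl in compound 3

A few compounds are considered here, and "the series" means these few. Any claim that something is new, unique, unknown or untested is made for them only; others in the source may bear on it.

Compound 1 `O=C(/C=C/c1cccs1)c1ccccc1OCC1CO1`: 17700 nM
Compound 2 `O=C(/C=C/c1ccco1)c1ccc(OCC2CO2)cc1`: 17700 nM
Compound 3 `O=C(/C=C/c1cccs1)c1ccc(OCC2CO2)cc1`: 17800 nM

In a functional assay on T47D cells (Homo sapiens) for inhibition, read by CCK-8 assay and cell counting, with a stated time of 2 days (on this read-out lower numbers stand for stronger inhibition and higher numbers for weaker inhibition), compound 3 stands level with the other two compounds, since all three values lie within the scatter of one another. Compound 4 `O=C(/C=C/c1ccoc1)c1ccc(OCC2CO2)cc1` carries furan-3-yl in place of thiophen-2-yl on a double-bonded chain carbon bound to a double-bonded chain carbon. For the measured compounds named here, one measured step bears on this change, an exchange of rings at that same place: a 1.0-fold higher number from compound 2 to compound 3 (0.00 log units; within the scatter). It stayed within the scatter. Going by the values given here, no measured compound carries furan-3-yl, so this step is only a partial guide. The expected change is no step beyond the scatter, a 1.0-fold lower number from compound 3 to compound 4 (0.02 log units; within the scatter). For compound 4 the estimated value is 17000 nM, with an expected range of 9000 nM to 32000 nM.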

Compound 4, half-maximal inhibitory concentration: 20600 nM
Compound 4: the middle estimate sits 1.2-fold (0.08 log units) below what was measured, within the range that was stated.
By their numbers in this assay, from the lowest: compounds 1, 2, 3 and 4 (each within the scatter of the next).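

Set against thiophen-2-yl and furan-2-yl in this assay, furan-3-yl gives a 1.2-fold higher number from compound 3 to compound 4 (0.06 log units; within the scatter) and a 1.2-fold higher number from compound 2 to compound 4 (0.07 log units; within the scatter) at this place, on a double-bonded chain carbon bound to a double-bonded chain carbon. All three five-membered rings therefore now sit within the scatter of one another, so this exchange of rings has not yet separated any of them. No measurement on hand explains this flat result. The compounds shown leave open whether a ring carrying an amine or a carboxylic acid at this place would give a step beyond the scatter.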